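The source may report more compounds than this note shows. Statements on the series, on what has been measured and on what is new or still open speak of the compounds shown alone.

Compound 1 `CS(=O)(=O)Nc1ccc(-c2nc3ccccc3o2)cc1`: in an assay on isolated protein for inhibition of malate dehydrogenase, mitochondrial (Sus scrofa), with stated times of 45 min and 30 min (on this read-out lower numbers stand for stronger inhibition and higher numbers for weaker inhibition), compound 1 gives > 63000 nM, a limit of the assay.
Compound 2 `CCc1ccc(S(=O)(=O)Nc2ccc(-c3nc4ccccc4o3)cc2)cc1`: in this assay compound 2 gives > 63000 nM, also a limit of the assay.

Compound 2 therefore stands at the limit of > 63000 nM in this assay, at which 2 of the 2 values shown sit, and no number is known for it. For the measured compounds named here, the only measured step, a step that the two limits leave unreadable from compound 1 to compound 2, runs from one limit to another and its size cannot be read. Compound 3 `O=S(=O)(Nc1ccc(-c2nc3ccccc3o2)cc1)c1ccc(F)cc1` differs from compound 2 by fluoro in place of ethyl on an aromatic carbon. Going by the values given here, no measured step bears on this change: the single step on record is unreadable, so neither direction nor size of a step in this assay can be taken from the numbers. With compound 2 sitting at the limit, compound 3 is expected to stay near or beyond that limit as well, with an expected step that the limit leaves unreadable from compound 2 to compound 3. The estimate for compound 3 is 100000 nM, with a range from 30000 nM to 400000 nM.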

Compound 3, half-maximal inhibitory concentration: > 63000 nM
Compound 3 was reported as a limit; the forecaster's own chance of this, stated with the estimate: 85%; the middle value lies beyond the limit too.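

In this assay compound 3 gives > 63000 nM, a limit of the assay. The steps from compound 1 and from compound 2 to compound 3 cannot be read: the limit of > 63000 nM in this assay, at which 3 of the 3 values shown sit.

The compounds shown leave open what number any of them would give in this assay, and whether changing the group on the sulfonyl sulfur alters inhibition at all.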